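Swapping a Ring Amine for an Open Chain Amine

This account rests on a few compounds, and the source may have more. Where it says the series, first, only, none or still open, it means among the compounds named here.

Compound 1 `O=C(CC(CC(=O)NC1Cc2ccccc2C1)c1ccccc1)NCCN1CCCC1` and compound 2 `CCN(CC)CCNC(=O)CC(CC(=O)NC1Cc2ccccc2C1)c1ccccc1` share a core and differ in one place only. In a functional assay on MGC-803 cells (Homo sapiens) for inhibition (on this read-out higher numbers stand for weaker inhibition and lower numbers for stronger inhibition), compound 1 gives > 100000 nM, which is a limit of the assay rather than a number. Compound 2 likewise reaches only a limit, > 100000 nM. The change between them, (diethylamino in place of pyrrolidin-1-yl on a saturated chain carbon, two bonds along the chain from an amide-type nitrogen), therefore yields a step that the two limits leave unreadable from compound 1 to compound 2. Compound 3 `CCN(C(=O)CC(CC(=O)NCCN1CCCC1)c1ccc(Cl)cc1)C1Cc2ccccc2C1` is built on a different core; how its core differs from that of compound 1 is not broken down here. In this assay, among the measured compounds shown here, compound 3 gives 55500 nM, the only plain number in this set, whereas the other two values are the limit of > 100000 nM in this assay, at which 2 of the 3 values shown sit. Compound 4 `CCN(CC)CCNC(=O)CC(CC(=O)N(CC)C1Cc2ccccc2C1)c1ccc(Cl)cc1` carries the same change, (diethylamino in place of pyrrolidin-1-yl on a saturated chain carbon, two bonds along the chain from an amide-type nitrogen). The step expected is a 1.3-fold higher number from compound 3 to compound 4 (0.10 log units; within the scatter), which rests on compound 3 at 55500 nM and on the unreadable a step that the two limits leave unreadable from compound 1 to compound 2. Compound 4 is accordingly estimated at 70000 nM, between 25000 nM and 200000 nM.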

Compound 4, half-maximal inhibitory concentration: 44900 nM
Compound 4: middle estimate off by 1.6-fold (0.19 log units), on the high side; the measured number falls inside the stated range.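

In this assay, diethylamino in place of pyrrolidin-1-yl on the core of compound 3 gives a 1.2-fold lower number from compound 3 to compound 4 (0.09 log units; within the scatter) and so leaves the number effectively unchanged on this core. This single readable step does not show that the change would behave the same way on other cores. The step on the core of compound 1 cannot be read, because compound 1 and compound 2 each give a limit of the assay rather than a number: the limit of > 100000 nM in this assay, at which 2 of the 4 values shown sit.

The compounds shown leave open whether another amine at this place, such as piperidin-1-yl or morpholin-4-yl, or a longer chain would move the value beyond the scatter. They also leave open whether any such change would have a readable effect on the core of compound 1.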